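The compounds below may be only part of what the source reports. "The series", "measured", "known", "first", "only" and "open" are said of these compounds alone.

Values measured so far in a functional assay on HCT-116 cells (Homo sapiens) for cytotoxicity, read by MTT assay, with a stated time of 72 h; a higher number here means a weaker inhibitor, a lower number a stronger inhibitor
compound 1 (`COc1ncc(-c2ccc3nc(NC(=O)N(C)C)nn3c2)cc1NS(=O)(=O)c1ccc(F)cc1`) gives 760 nM
compound 2 (`COc1ncc(-c2ccc3nc(NC(=O)NC4CC4)nn3c2)cc1NS(=O)(=O)c1ccc(F)cc1`) gives 90 nM
compound 3 (`COc1ncc(-c2ccc3nc(NC(=O)NCCN4CCCCC4)nn3c2)cc1NS(=O)(=O)c1ccc(F)cc1`) gives 150 nM

Compound 3 (150 nM) belongs to the lower pair of these values, with gaps of (a 1.7-fold higher number from compound 2 to compound 3 (0.22 log units; within the scatter)) and (a 5.1-fold lower number from compound 1 to compound 3 (0.70 log units; beyond the scatter)) to the other two. Compound 4 (`CCCNC(=O)Nc1nc2ccc(-c3cnc(OC)c(NS(=O)(=O)c4ccc(F)cc4)c3)cn2n1`) carries methyl in place of piperidin-1-yl on a saturated chain carbon, two bonds along the chain from an amide-type nitrogen, so that 2-(piperidin-1-yl)ethyl becomes propyl. Among the measured compounds shown here, no measured step makes this exact change. The closest evidence is the exchange of cyclopropyl for 2-(piperidin-1-yl)ethyl on that nitrogen (a 1.7-fold higher number from compound 2 to compound 3 (0.22 log units; within the scatter)), which stayed within the scatter. Replacing dimethylamino gave larger, modest steps (an 8.4-fold lower number from compound 1 to compound 2 (0.93 log units; beyond the scatter)) and (a 5.1-fold lower number from compound 1 to compound 3 (0.70 log units; beyond the scatter)). Propylamino is expected to behave more like the groups of compound 2 (90 nM) and compound 3 (150 nM) than like the dimethylamino of compound 1 (760 nM). In this assay no change beyond the scatter is therefore expected, and the estimated step is small (a 1.3-fold lower number from compound 3 to compound 4 (0.10 log units; within the scatter)). The expected value for compound 4 is 120 nM in an estimated range from 45 nM to 320 nM and awaits measurement.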

Compound 4, half-maximal inhibitory concentration: 150 nM
The estimate for compound 4 lay 1.3-fold (0.10 log units) below the measured number; the range from low to high includes it.
By their numbers in this assay, from the lowest: compounds 2, 3 and 4 (each within the scatter of the next); then compound 1.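

In this assay, taking away the piperidin-1-yl ring, with its six heavy atoms and its hydrogen-bond acceptor, leaves the read-out where it was (no change at the digits printed from compound 3 to compound 4 (within the scatter)), so this ring at the end of the chain is not required for the activity seen here, and a plain propyl serves equally well. Propyl also sits within the scatter of the cyclopropyl group on the amide-type nitrogen (a 1.7-fold higher number from compound 2 to compound 4 (0.22 log units; within the scatter)), while the gap to dimethylamino persists (a 5.1-fold lower number from compound 1 to compound 4 (0.70 log units; beyond the scatter)); a ring, an open chain and a chain ending in an amine thus all read alike at this position, and among the four compounds only compound 1 stands apart. Nothing given here explains why these groups read alike.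

From the compounds shown here alone, it stays open whether this tolerance extends to a chain ending in a carboxylic acid or a morpholine ring, or to a chain longer than propyl. It is also open whether methylamino would read like propylamino or like the dimethylamino of compound 1, and the compounds shown do not separate the size of the group from the second methyl on that nitrogen.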